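The source may hold more compounds than are shown below. What is called first, only, known or untested is meant among the compounds shown, and "the series" means these compounds.

Measured in an in vitro ADME assay on microsomes from liver (Rattus norvegicus) for metabolic stability; a lower number here means that the compound disappears faster, a higher number that the compound lasts longer:
- compound 1 `CNc1nc(NCc2ccc(NC(=O)c3ccc(F)cc3)cc2)c2ccccc2n1`: 0.35 h
- compound 2 `CNc1nc(NCc2ccc(NC(=O)c3ccc(F)cc3)cc2)c2ccc(C)cc2n1`: > 0.5 h (a limit, not a number)
- compound 3 `CNc1nc(NCc2ccc(NC(=O)c3ccc(Cl)nc3)cc2)c2ccc(C)cc2n1`: 0.133 h

Compound 2 stands on (the limit of > 0.5 h in this assay, at which 1 of the 3 values shown sits), so its position in this assay is known only as a limit.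

Compound 4 `Cc1ccc2c(NCc3ccc(NC(=O)c4ccc(F)cc4)cc3)nc(N3CCCC3)nc2c1` is still unmeasured. It carries pyrrolidin-1-yl in place of methylamino on an aromatic carbon, between two ring nitrogen atoms, and otherwise matches compound 2: pyrrolidin-1-yl in place of methylamino on an aromatic carbon.

Two measured steps are available, and neither touches this place. Methyl in place of hydrogen on an aromatic carbon gave an at least 1.4-fold higher number from compound 1 to compound 2 (0.15 log units; that floor lies within the scatter). Replacing 4-fluorophenyl with 6-chloropyridin-3-yl at the carbonyl gave an at least 3.7-fold lower number from compound 2 to compound 3 (0.57 log units; beyond the scatter). These steps therefore bear on the change only indirectly, as a guide to how far numbers move within the series. The second step is the only one shown to lie beyond the scatter, and it sets a rough ceiling for the size expected here.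

A modest move towards a lower number is expected, though a result within the scatter of the limit would not be surprising. The estimated change is an at least 1.4-fold lower number from compound 2 to compound 4 (0.15 log units; that floor lies within the scatter). For compound 4 the expected value is 0.35 h, with an estimated range of 0.14 h to 0.8 h.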

Compound 4, half-life: 0.0333 h
Estimate against measurement, compound 4: 11-fold (1.02 log units) above; the whole stated range lies above it.
By their numbers in this assay, from the lowest: compound 4; then compound 3; then compound 1. At a limit, above all of these: compound 2.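

In this assay, the aromatic carbon between two ring nitrogen atoms is a place where a single change moves the number strongly: pyrrolidin-1-yl in place of methylamino gives an at least 15-fold lower number from compound 2 to compound 4 (1.17 log units; beyond the scatter). Among these compounds, the earlier steps concerned a methyl on the shared core and the group on the carbonyl, so this is the first reading at this place, and it shows that the group here cannot be treated as a neutral handle for stability in this assay. The printed size of the step is only a floor, because the value of compound 2 is a limit: the limit of > 0.5 h in this assay, at which 1 of the 4 values shown sits.

The change adds a five-membered non-aromatic ring, adds heavy atoms and removes the hydrogen-bond donor all at once, so the compounds shown cannot say which of these goes with the lower number; dimethylamino, azetidin-1-yl or morpholin-4-yl at this place would begin to separate them. Also open, from the compounds shown here alone, is whether the same change at this place moves the number as far when 6-chloropyridin-3-yl stands on the carbonyl.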